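Swapping a styryl tail for a bromophenyl on a hydrazone

The source may hold more compounds than are shown below. What is called first, only, known or untested is meant among the compounds shown, and "the series" means these compounds.

Of the compounds shown here, three sharing one core have been tested in an ADME assay on HEL cells (Homo sapiens) for cytotoxicity; a lower number here means that less compound is tolerated, a higher number that more compound is tolerated. Compound 1 `O=C(COc1cccc2ccccc12)N/N=C/c1ccc(O)cc1` gives 60.6 ug/mL. Compound 2 `Cc1ccc(/C=N/NC(=O)COc2cccc3ccccc23)cc1` gives 80.1 ug/mL. Compound 3 `O=C(COc1cccc2ccccc12)N/N=C/C=C/c1ccccc1` gives 100 ug/mL, the highest of the three numbers, though its nearest neighbour is compound 2 and its furthest is compound 1, and both gaps stay within the scatter, so no ordering among the three can be claimed.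

The next compound, compound 4 `O=C(COc1cccc2ccccc12)N/N=C/c1cccc(Br)c1`, differs from compound 3 in one place: 3-bromophenyl in place of 2-phenylethenyl on a carbon with a double bond to nitrogen. Among the measured compounds shown here, two measured steps bear on this change. Each of them also replaces the group on the carbon with a double bond to nitrogen. The step of a 1.7-fold higher number from compound 1 to compound 3 (0.22 log units; within the scatter) and the step of a 1.2-fold higher number from compound 2 to compound 3 (0.10 log units; within the scatter) both introduced the 2-phenylethenyl group and both stayed within the scatter. For the measured compounds named here, compound 4 goes the other way, removing that group in favour of a 3-bromophenyl, and no measured step carries a bromine. On this evidence the expected step of a 1.3-fold lower number from compound 3 to compound 4 (0.12 log units; within the scatter) is a small one, leaning slightly downward but not beyond the scatter. The estimate for compound 4 in this assay is therefore 75 ug/mL, with a range from 45 ug/mL to 130 ug/mL.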

Compound 4, half-maximal cytotoxic concentration: 48.6 ug/mL
Compound 4: middle estimate off by 1.5-fold (0.19 log units), on the high side, and the stated range covers the measured number.
By their numbers in this assay, from the lowest: compounds 4, 1, 2 and 3 (each within the scatter of the next, the first and the last beyond it).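

At the carbon with a double bond to nitrogen, this assay now shows its first step beyond the scatter (a 2.1-fold lower number from compound 3 to compound 4 (0.31 log units; beyond the scatter)), so replacing 2-phenylethenyl with 3-bromophenyl has a modest but readable effect on the number, which none of the earlier changes had. Swapping one substituted phenyl for another at this carbon still gives no separation (a 1.6-fold lower number from compound 2 to compound 4 (0.22 log units; within the scatter); a 1.2-fold lower number from compound 1 to compound 4 (0.10 log units; within the scatter)), as both steps stay within the scatter, and 3-bromophenyl cannot be told apart from 4-methylphenyl or 4-hydroxyphenyl on this evidence. Nothing measured here explains why the step from 2-phenylethenyl to 3-bromophenyl is the one that stands out.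

The compounds shown leave open whether this step comes from losing 2-phenylethenyl or from bringing in bromine, a question that a plain phenyl group at the same carbon would help to settle. They also leave open how this assay would respond to a group of another kind at this carbon, such as a phenyl ring carrying an amine or a carboxylic acid.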